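The source may hold more compounds than are shown below. What is called first, only, known or untested is meant among the compounds shown, and "the series" means these compounds.

Measured so far:
compound 1, `COc1ccccc1C(=O)NCCNc1cccc(NS(=O)(=O)c2cc(-c3cccc(C(=O)N(C)C)c3)ccc2OC)c1`: 50 nM in an assay on CHO-K1 cells for agonist activity at Orexin receptor type 2 (Homo sapiens), read by a luciferase reporter; a lower number here means that less compound is needed, a higher number that more compound is needed for the effect
compound 2, `COc1ccccc1C(=O)NCCNc1cccc(NS(=O)(=O)c2cc(-c3cccc(F)c3)ccc2OC)c1`: > 10000 nM in this assay, a limit of the assay
compound 3, `COc1ccc(C(=O)NCCNc2cccc(NS(=O)(=O)c3cc(-c4cccc(C(=O)N(C)C)c4)ccc3OC)c2)cc1`: 1050 nM in this assay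

Of the two numbers in this assay compound 3 carries the highest; the nearest is that of compound 1, reached by the step of a 21-fold higher number from compound 1 to compound 3 (1.32 log units; beyond the scatter). Compound 2 reports only a limit, (the limit of > 10000 nM in this assay, at which 1 of the 3 values shown sits), and gives no number to rank.

Compound 4, `COc1ccc(-c2cccc(C(=O)N(C)C)c2)cc1S(=O)(=O)Nc1cccc(NCCNC(=O)c2ccccc2Cl)c1`, is still to be measured. It differs from compound 3 as follows: 2-chlorophenyl in place of 4-methoxyphenyl on a carbonyl carbon. Of the measured steps, only one touches this carbonyl carbon: a 21-fold higher number from compound 1 to compound 3 (1.32 log units; beyond the scatter), a large rise when the 2-methoxyphenyl is exchanged for the 4-methoxyphenyl. The other step, an at least 200-fold higher number from compound 1 to compound 2 (2.30 log units; beyond the scatter), lies on the dimethylcarbamoyl of the biaryl, which compound 3 and compound 4 share, so it says nothing about this change.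

Compound 4 returns a substituent to the 2-position of the phenyl, now chlorine in place of the methoxy, so a step back toward the number of compound 1 is expected, though the chlorine is not the methoxy and a full return is not assumed. The step from compound 3 to compound 4 in this assay is expected to be a 7.0-fold lower number from compound 3 to compound 4 (0.85 log units; beyond the scatter). Compound 4 is therefore estimated at 150 nM, within 40 nM to 700 nM.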

Compound 4, half-maximal effective concentration: 31 nM
Estimate against measurement, compound 4: 4.8-fold (0.68 log units) above; measured number below the stated range.
By their numbers in this assay, from the lowest: compounds 4 and 1 (each within the scatter of the next); then compound 3. At a limit, above all of these: compound 2.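

In this assay, 2-chlorophenyl in place of 4-methoxyphenyl on the carbonyl carbon gives a 34-fold lower number from compound 3 to compound 4 (1.53 log units; beyond the scatter), so the large rise seen on leaving 2-methoxyphenyl is reversed by a group that is not a methoxy at all. Chloro in place of methoxy on the aromatic carbon gives a 1.6-fold lower number from compound 1 to compound 4 (0.21 log units; within the scatter), which leaves compound 1 and compound 4 indistinguishable in this assay; the 2-chlorophenyl counts 0 hydrogen-bond acceptors, so an oxygen on this phenyl is not required for a number at this level. Among compound 1, compound 3 and compound 4, the two 2-substituted phenyls sit together and the 4-substituted one stands apart, although the step to compound 4 changes the substituent and its place at once, and no compound here separates the two changes.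

Nothing shown bears on why these steps are so large. Still open, going by these compounds, are how 4-chlorophenyl, unsubstituted phenyl, 2-methylphenyl or 2-aminophenyl would read on this carbonyl carbon, and whether the 2-chlorophenyl keeps its number when the dimethylcarbamoyl of the shared core is replaced by a carboxylic acid or a fluoro.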